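A few compounds are considered here, and "the series" means these few. Any claim that something is new, unique, unknown or untested is made for them only; others in the source may bear on it.

Three compounds sharing one core were tested in a functional assay on HL-60 cells (Homo sapiens) for inhibition, read by CCK-8 assay, with a stated time of 48 h, tested at 20 uM; on this read-out higher numbers stand for more inhibition of growth at the one concentration tested and lower numbers for less inhibition of growth. In this assay, compound 1 (`Cc1ccc(S(=O)(=O)Oc2ccccc2/C=C(\C#N)C(=O)Nc2nnc(Cc3ccc(F)cc3)s2)cc1`) gave "not active" (no number reported), so it provides no number for comparison. Compound 2 (`N#C/C(=C\c1ccccc1OS(=O)(=O)c1ccc([N+](=O)[O-])cc1)C(=O)Nc1nnc(Cc2ccc(F)cc2)s1`) gave 18%, and compound 3 (`N#C/C(=C\c1ccccc1OS(=O)(=O)c1ccccc1[N+](=O)[O-])C(=O)Nc1nnc(Cc2ccc(F)cc2)s1`) gave 35%, the higher of the two numbers available.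

The next compound to be considered is compound 4 (`N#C/C(=C\c1ccccc1OS(=O)(=O)c1ccccc1[N+](=O)[O-])C(=O)Nc1nnc(Cc2cccc(F)c2)s1`), which has the same atoms as compound 3, joined differently: 3-fluorophenyl in place of 4-fluorophenyl on a saturated chain carbon bound to an aromatic carbon. In words, 3-fluorophenyl stands in place of 4-fluorophenyl on a saturated chain carbon bound to an aromatic carbon.

For the measured compounds named here, only one measured step offers any guide: a number 17 percentage points higher from compound 2 to compound 3 (beyond the scatter). That modest step came from placing 2-nitrophenyl in place of 4-nitrophenyl on a sulfonyl sulfur, so it shows that such an exchange of isomeric groups can matter in this series. However, it concerns a different group at a different place, and no measured pair varies the fluorophenyl group. A step of similar size is therefore possible in either direction, but no step beyond the scatter is the expectation. The estimated change is a number 3 percentage points lower from compound 3 to compound 4 (within the scatter). For compound 4, the expected value is 32%, with an estimated range from 14% to 52%.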

Compound 4, percent growth inhibition at one concentration: 23%
The estimate for compound 4 lay 9 percentage points above the measured number, within the range that was stated.
By their numbers in this assay, from the lowest: compounds 2 and 4 (each within the scatter of the next); then compound 3.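

In this assay, the exchange of 4-fluorophenyl for 3-fluorophenyl on a saturated chain carbon bound to an aromatic carbon gave a number 12 percentage points lower from compound 3 to compound 4 (beyond the scatter) and so lowered growth inhibition at the one concentration tested. Compounds 1, 2 and 3 all carry 4-fluorophenyl and could not speak to this place; the new pair shows that it also responds to an exchange of isomeric groups, even though the two groups match in every count computed for them. No evidence is available that bears on the reason for this step.

The compounds shown leave open how an unsubstituted phenyl, a chlorophenyl or a longer chain carrying the aromatic ring would fare at this place, and whether an amine or a carboxylic acid on that ring would be tolerated. They also leave open whether the same exchange would give a step of similar size with 4-nitrophenyl on the sulfonyl sulfur, since the fluorophenyl group has so far been varied only with 2-nitrophenyl there.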